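Fluorophenyl sulfide analogue in the quinoxaline diamine series

The source may hold more compounds than are shown below. What is called first, only, known or untested is meant among the compounds shown, and "the series" means these compounds.

Compound 3 `Nc1cc(N)c2nc(-c3ccccc3)c(Oc3ccc(F)cc3)nc2c1` gives in a functional assay on K562 cells (Homo sapiens) for inhibition, read by sulforhodamine B assay, with a stated time of 48 h (a higher number here means that more compound is tolerated, a lower number that less compound is tolerated), a value that is a limit of the assay, < 100000 nM. Compound 1 `Nc1cc(N)c2nc(-c3ccccc3)c(NCc3ccc(F)cc3)nc2c1` gives in this assay likewise a limit, < 100000 nM. Compound 2 `COc1ccc(Sc2nc3cc(N)cc(N)c3nc2-c2ccccc2)cc1` also gives a limit, < 100000 nM. Accordingly the steps a step that the two limits leave unreadable from compound 1 to compound 2, a step that the two limits leave unreadable from compound 1 to compound 3 and a step that the two limits leave unreadable from compound 2 to compound 3 are unreadable; see (the limit of < 100000 nM in this assay, at which 3 of the 3 values shown sit). Compound 4 `Nc1cc(N)c2nc(-c3ccccc3)c(Sc3ccc(F)cc3)nc2c1` differs from compound 3 by (4-fluorophenyl)sulfanyl in place of 4-fluorophenoxy on an aromatic carbon. Among the measured compounds shown here, no measured step reads on this change, so no direction beyond the scatter is expected; compound 4 is expected to sit near the same limit, giving an estimated step that the limit leaves unreadable from compound 3 to compound 4. The estimate for compound 4 is 30000 nM, ranging from 5000 nM to 100000 nM.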

Compound 4, concentration lethal to 50% of the cells: < 100000 nM
Compound 4 gave a limit, no number; the forecaster's own chance of this, stated with the estimate: 70%; the middle value lies beyond the limit too.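

In this assay, among the compounds shown here, compound 4 gives < 100000 nM, a limit of the assay, so no step among compound 1, compound 2, compound 3 and compound 4 can be read: the limit of < 100000 nM in this assay, at which 4 of the 4 values shown sit. What (4-fluorophenyl)sulfanyl in place of 4-fluorophenoxy, or any other change shown, does to the lethal concentration stays open.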